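Aryl variation on the shared core: expectation for compound 4

This account rests on a few compounds, and the source may have more. Where it says the series, first, only, none or still open, it means among the compounds named here.

Measured so far in an assay on Sf9 cells for inhibition of protein deacetylase HDAC6 (Homo sapiens), read by fluorescence, with a stated time of 40 min, tested at 100 nM; a higher number here means more inhibition at the concentration tested (going by the name of the read-out), a lower number less inhibition:
compound 1, `O=C(NO)c1ccc(NCc2nc(-c3cccc(Cl)c3)nn2-c2ccccc2)cc1`, compound 1 gives 61.2%
compound 2, `O=C(NO)c1ccc(NCc2nc(-c3cc4ccccc4s3)nn2-c2ccccc2)cc1`, compound 2 gives 65.5%
compound 3, `Cc1ccccc1-c1nc(CNc2ccc(C(=O)NO)cc2)n(-c2ccccc2)n1`, compound 3 gives 53.2%

Compound 3 holds the lowest of the three numbers. Against compound 1 the gap is small: a number 8 percentage points lower from compound 1 to compound 3 (within the scatter). Against compound 2 it is larger: a number 12.3 percentage points lower from compound 2 to compound 3 (beyond the scatter). The two groups closest in size to each other, in compounds 1 and 2, give a number 4.3 percentage points higher from compound 1 to compound 2 (within the scatter).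

Compound 4, `O=C(NO)c1ccc(NCc2nc(-c3ccncc3)nn2-c2ccccc2)cc1`, is not yet measured. It differs from compound 3 in one place: pyridin-4-yl in place of 2-methylphenyl on an aromatic carbon.

All three measured steps exchange the group on this same aromatic carbon, so all three bear on the change, and all three are modest: the whole spread of the series fits inside the numbers of compounds 3 and 2. Among the measured compounds shown here, no measured step involves pyridin-4-yl, so its own effect is unknown. The expectation is therefore a step of about the size already seen for aryl exchanges, with no clear direction; the estimated step is a number 2.8 percentage points higher from compound 3 to compound 4 (within the scatter), within the scatter. For compound 4 the estimated value is 56%, with a range from 40% to 72%.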

Compound 4, a percentage reported as inhibition, at one concentration (the size of the read-out at that concentration, not a potency): 30.8%
Compound 4: middle estimate off by 25.2 percentage points, on the high side; measured number outside the range, below it.
By their numbers in this assay, from the lowest: compound 4; then compounds 3, 1 and 2 (each within the scatter of the next, the first and the last beyond it).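

In this assay this position, the aromatic carbon of the five-membered ring, no longer looks indifferent to the aryl group: pyridin-4-yl gives a number 22.4 percentage points lower from compound 3 to compound 4 (beyond the scatter), a number 30.4 percentage points lower from compound 1 to compound 4 (beyond the scatter) and a number 34.7 percentage points lower from compound 2 to compound 4 (beyond the scatter). Among the compounds shown here, the earlier exchanges among 3-chlorophenyl, 1-benzothiophen-2-yl and 2-methylphenyl included no large step, so the position's sensitivity appears only with this group, the only one of the four with a ring nitrogen, although that link rests on a single compound. Nothing available on these compounds accounts for the loss of inhibition.

The compounds shown leave open whether the loss follows the ring nitrogen itself or its place in the ring, a question that pyridin-3-yl and pyridin-2-yl at this carbon would address, with unsubstituted phenyl as the direct carbon-only partner of compound 4. Also open, as far as these compounds go, is whether an amine or a carboxylic acid on a phenyl ring here would track with pyridin-4-yl or with the other three groups, and how these single-concentration percentages relate to potency.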